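The source may report more compounds than this note shows. Statements on the series, on what has been measured and on what is new or still open speak of the compounds shown alone.

Measured so far in a functional assay on SW480 cells (Homo sapiens) for cytotoxicity, read by MTT assay, with a stated time of 48 h; a lower number here means a stronger inhibitor, a higher number a weaker inhibitor:
- compound 1, `O=c1ccoc2cc(OCc3cn(Cc4ccccc4)nn3)ccc12`: 42900 nM
- compound 2, `O=c1ccoc2cc(OCc3cn(Cc4ccc(Cl)cc4)nn3)ccc12`: > 100000 nM, which is a limit of the assay and not a number
- compound 3, `O=c1ccoc2cc(OCc3cn(Cc4cccc(F)c4)nn3)ccc12`: > 100000 nM, likewise a limit

Compound 2 therefore stands at the limit of > 100000 nM in this assay, at which 2 of the 3 values shown sit, with only compound 1 giving a read number. The step from compound 1 to compound 2 was an at least 2.3-fold higher number from compound 1 to compound 2 (0.36 log units; beyond the scatter), and the step from compound 1 to compound 3 was an at least 2.3-fold higher number from compound 1 to compound 3 (0.36 log units; beyond the scatter); between compound 2 and compound 3 the step is a step that the two limits leave unreadable from compound 2 to compound 3. Compound 4, `CC(C)(C)c1ccc(Cn2cc(COc3ccc4c(=O)ccoc4c3)nn2)cc1`, differs from compound 2 by tert-butyl in place of chloro on an aromatic carbon. Nothing measured reaches past the limit in this direction, so compound 4 is expected to remain at or near it, with a step of a number no higher from compound 2 to compound 4 (the limit leaves the size open) that is estimated as none beyond the scatter. Compound 4 is thus expected to give about 100000 nM, between 30000 nM and 300000 nM.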

Compound 4, half-maximal inhibitory concentration: 28800 nM
Beside the measured number, compound 4's estimate is 3.5-fold (0.54 log units) above it, and the stated range ends above it.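

Compound 2 stands as a limit of the assay and not a number in this assay: the limit of > 100000 nM in this assay, at which 2 of the 4 values shown sit.

At the aromatic carbon para to a large group, tert-butyl in place of chloro comes back from that limit, with an at least 3.4-fold lower number from compound 2 to compound 4 (0.54 log units; beyond the scatter). Tert-butyl in place of hydrogen gives a 1.5-fold lower number from compound 1 to compound 4 (0.17 log units; within the scatter), so at this place chloro reaches the limit while tert-butyl does not.

The compounds shown leave open whether an amine or a methoxy group here would follow chloro or tert-butyl. They also leave open whether any group at this place could move the number beyond the scatter from compound 1.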